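Aryl variation on the core: trifluoromethyl in place of fluorine

The compounds below may be only part of what the source reports. "The series", "measured", "known", "first", "only" and "open" are said of these compounds alone.

Compound 3 `CN(C)CCCCOC(=O)Nc1ccc(Cn2nc(-c3cccc(F)c3)c3ccccc3c2=O)cc1` gives 37400 nM in an ADME assay on Huh-7 cells (Homo sapiens) for cytotoxicity, read by MTT assay, with a stated time of 48 h; a higher number here means that more compound is tolerated, a lower number that less compound is tolerated. Among the three measured compounds it sits close to compound 1 `CN(C)CCCCOC(=O)Nc1ccc(Cn2nc(-c3cccnc3)c3ccccc3c2=O)cc1`, which gives 68000 nM, the two differing only within the scatter, while compound 2 `CN(C)CCCCOC(=O)Nc1ccc(Cn2nc(-c3ccccc3)c3ccccc3c2=O)cc1` gives 16000 nM, with a 2.3-fold higher number from compound 2 to compound 3 (0.37 log units; beyond the scatter). Compound 4 `CN(C)CCCCOC(=O)Nc1ccc(Cn2nc(-c3ccccc3C(F)(F)F)c3ccccc3c2=O)cc1` carries 2-(trifluoromethyl)phenyl in place of 3-fluorophenyl on an aromatic carbon. Every measured step changes this same aryl group: a 4.3-fold lower number from compound 1 to compound 2 (0.63 log units; beyond the scatter), a 1.8-fold lower number from compound 1 to compound 3 (0.26 log units; within the scatter) and a 2.3-fold higher number from compound 2 to compound 3 (0.37 log units; beyond the scatter) were modest at most. A change of similar size, or none beyond the scatter, is therefore expected in this assay, with a 1.2-fold lower number from compound 3 to compound 4 (0.10 log units; within the scatter). Compound 4 is estimated at 30000 nM, within 12000 nM to 75000 nM.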

Compound 4, half-maximal cytotoxic concentration: 35700 nM
Beside the measured number, compound 4's estimate is 1.2-fold (0.08 log units) below it; low and high end bracket the measured number.
By their numbers in this assay, from the lowest: compound 2; then compounds 4, 3 and 1 (each within the scatter of the next).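

In this assay the aryl position on the shared core accepts 2-(trifluoromethyl)phenyl in place of 3-fluorophenyl with no change beyond the scatter (a 1.0-fold lower number from compound 3 to compound 4 (0.02 log units; within the scatter)). Both substituted phenyl groups now give higher numbers than plain phenyl, trifluoromethyl in place of hydrogen giving a modest step (a 2.2-fold higher number from compound 2 to compound 4 (0.35 log units; beyond the scatter)), while the step from pyridin-3-yl stays within the scatter (a 1.9-fold lower number from compound 1 to compound 4 (0.28 log units; within the scatter)). No measurement shown explains these numbers.

Still open, going by these compounds, is whether an amine or a carboxylic acid on this phenyl ring would move the number beyond this narrow range.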